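This account rests on a few compounds, and the source may have more. Where it says the series, first, only, none or still open, it means among the compounds named here.

Of the compounds shown here, two of a shared core have been measured in a functional assay for agonist activity at G protein-coupled receptor 88 (Homo sapiens), read by HTRF and cAMP accumulation; on this read-out lower numbers stand for an effect already at smaller amounts and higher numbers for an effect only at larger amounts of compound. Compound 1 `CC[C@H](C)[C@H](N)CN(C(=O)[C@@H]1C[C@H]1c1nc(C)c(C)s1)c1ccc(-c2ccccc2)cc1` gives 3600 nM in this assay. Compound 2 `CC(C)C[C@H](N)CN(C(=O)[C@@H]1C[C@H]1c1ccccc1)c1ccc(-c2cccnc2)cc1` gives 10000 nM in this assay, the higher of the two numbers; its gap to compound 1 lies beyond the usual scatter of repeated measurements, so compound 2 shows the weaker effect of the pair on the evidence at hand. For the measured compounds named here, the two compounds differ in more than one place, so no single step between them can be read off.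

Compound 3 `CC(C)C[C@H](N)CN(C(=O)[C@@H]1C[C@H]1c1ccccc1)c1ccc(-c2ccoc2)cc1` has not yet been measured. It differs from compound 2 in one place: furan-3-yl in place of pyridin-3-yl on an aromatic carbon. Going by the values given here, no measured pair in this set isolates such an exchange, so there is nothing to carry over from it. On that footing, the step from compound 2 to compound 3 is expected to be small, a 1.3-fold lower number from compound 2 to compound 3 (0.10 log units; within the scatter), not beyond the scatter in either direction. For compound 3 the expected value in this assay is therefore 8000 nM, with a range from 2500 nM to 25000 nM.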

Compound 3, half-maximal effective concentration: 2000 nM
For compound 3 the middle estimate is 4.0-fold (0.60 log units) above the measured one; the measured number lies below the stated range.
By their numbers in this assay, from the lowest: compounds 3 and 1 (each within the scatter of the next); then compound 2.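

In this assay, the exchange of pyridin-3-yl for furan-3-yl gives a 5.0-fold lower number from compound 2 to compound 3 (0.70 log units; beyond the scatter), the first single-place change readable in this set, and it shows that the aromatic ring on this carbon, para to a large group, affects the number beyond the scatter. The two groups have the same counts of hydrogen-bond donors and acceptors and no net charge, so those counts do not distinguish them; they differ in ring size, in the hetero atom, and by one heavy atom. Nothing available here bears on why the number moved.

The compounds shown leave open whether the step follows the five-membered ring or the oxygen, since the exchange changes both at once; a thiophen-3-yl would keep the five-membered aromatic ring with sulfur as its hetero atom, while a pyrrol-3-yl would keep it with nitrogen. They also leave open whether furan-3-yl would bring a step of similar size on the core of compound 1, which differs from compound 3 in more than one place.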